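This account rests on a few compounds, and the source may have more. Where it says the series, first, only, none or still open, it means among the compounds named here.

Compound 1 `COc1cc([C@@H]2CCc3cc(O)c(OC)cc3O2)ccc1O` and compound 2 `COc1cc(OC)c2c(c1)O[C@H](c1ccc(O)c(O)c1)CC2` have been measured in a functional assay on KB cells (Homo sapiens) for cytotoxicity, read by colorimetric assay; on this read-out lower numbers stand for stronger inhibition and higher numbers for weaker inhibition. Compound 1 gives 69000 nM, the higher of the two numbers; compound 2 gives 31800 nM, and the gap between them lies beyond the scatter. Compound 3 `COc1cc([C@@H]2CCc3cc(OC)c(OC)cc3O2)ccc1O` differs from compound 1 by methyl in place of hydrogen on an oxygen on an aromatic ring. Among the compounds with values here, no step of this kind has been measured, so its size is uncertain; a small shift toward a higher number, or none beyond the scatter, is expected. Compound 3 is estimated at 80000 nM in this assay, within 25000 nM to 250000 nM, which means an expected step of a 1.2-fold higher number from compound 1 to compound 3 (0.06 log units; within the scatter).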

Compound 3, half-maximal inhibitory concentration: 106000 nM
Beside the measured number, compound 3's estimate is 1.3-fold (0.12 log units) below it, and the stated range covers the measured number.
By their numbers in this assay, from the lowest: compound 2; then compounds 1 and 3 (each within the scatter of the next).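

Replacing hydroxy with methoxy at this position provides the series' first one-place comparison: in this assay the change gives a 1.5-fold higher number from compound 1 to compound 3 (0.19 log units; within the scatter). On this single pair, methyl in place of hydrogen on this oxygen leaves the number within the scatter, so this hydrogen shows no measurable role in this read-out. Nothing at hand accounts for the size of this step.

On these data alone, whether an ethyl group or a longer chain on this oxygen, or an amine or fluorine in place of the hydroxy, would move the number beyond the scatter remains open. This single pair also leaves open how the same change would read at the other hydroxy groups.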